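Swapping the amide aryl group of compound 2 for fluorophenyl

The source may report more compounds than this note shows. Statements on the series, on what has been measured and on what is new or still open speak of the compounds shown alone.

The shared core appears in compound 1 `COc1ccc(CNC(=O)/C=C/c2coc3cc(O)ccc3c2=O)cc1`, which in a functional assay (QGY7701 cells, Homo sapiens) for inhibition, read by MTT assay, with a stated time of 48 h (a higher number here means a weaker inhibitor, a lower number a stronger inhibitor), gives 10000 nM. Compound 3 `O=C(/C=C/c1coc2cc(O)ccc2c1=O)NCc1ccc(F)cc1` differs from it by fluoro in place of methoxy on an aromatic carbon, and in this assay compound 3 gives only a limit of the assay, > 100000 nM. That change produces an at least 10-fold higher number from compound 1 to compound 3 (1.00 log units; beyond the scatter). Compound 2 `COc1ccc2c(=O)c(/C=C/C(=O)Nc3cc(C)ccc3C)coc2c1` also stands at a limit of the assay, since in this assay compound 2 gives > 100000 nM. This is the limit of > 100000 nM in this assay, at which 2 of the 3 values shown sit.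

Compound 4 `COc1ccc2c(=O)c(/C=C/C(=O)Nc3ccc(F)cc3)coc2c1` is not yet measured. It differs from compound 2 by 4-fluorophenyl in place of 2,5-dimethylphenyl on an amide-type nitrogen. For the measured compounds named here, no measured step touches this position, so the only guide is an at least 10-fold higher number from compound 1 to compound 3 (1.00 log units; beyond the scatter), where fluoro entering coincided with a weaker result, and the fact that compound 2 already sits at the limit. Compound 4 is therefore expected to remain at or near that limit, with the estimated step of a number no higher from compound 2 to compound 4 (the limit leaves the size open) showing nothing beyond the scatter. For compound 4 the estimate in this assay is 100000 nM, in a range from 30000 nM to 300000 nM.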

Compound 4, half-maximal inhibitory concentration: > 100000 nM
Compound 4 ended at the assay's limit; the forecaster's own chance of this, stated with the estimate: 70%; the middle value sits exactly at the limit.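

In this assay, no step can be read from compound 2 to compound 4, because both values are limits of the assay rather than numbers: the limit of > 100000 nM in this assay, at which 3 of the 4 values shown sit. The compounds shown leave open how 4-fluorophenyl and 2,5-dimethylphenyl on the amide-type nitrogen compare.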